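Adding a second trifluoromethyl to compound 2

A few compounds are considered here, and "the series" means these few. Any claim that something is new, unique, unknown or untested is made for them only; others in the source may bear on it.

Compound 1 `O=C(Nc1ccccc1)c1ccc([N+](=O)[O-])o1`: > 20000 nM
Compound 2 `O=C(Nc1cccc(C(F)(F)F)c1)c1ccc([N+](=O)[O-])o1`: > 20000 nM
Compound 3 `COc1cccc(NC(=O)c2ccc([N+](=O)[O-])o2)c1`: > 20000 nM

In an ADME assay on HeLa cells (Homo sapiens) for cytotoxicity, read by resazurin assay, with a stated time of 65 h (a lower number here means that less compound is needed, a higher number that more compound is needed for the effect), compound 2 stands only at a limit, > 20000 nM. Among the measured compounds shown here, the whole series so far rests on (the limit of > 20000 nM in this assay, at which 3 of the 3 values shown sit). Compound 4 `O=C(Nc1cc(C(F)(F)F)cc(C(F)(F)F)c1)c1ccc([N+](=O)[O-])o1` differs from compound 2 by trifluoromethyl in place of hydrogen on an aromatic carbon, with trifluoromethyl in place of hydrogen on an aromatic carbon, meta to a trifluoromethyl group. For the measured compounds named here, the closest precedent is a step that the two limits leave unreadable from compound 1 to compound 2, the same exchange. Neither a step that the two limits leave unreadable from compound 1 to compound 3 nor a step that the two limits leave unreadable from compound 2 to compound 3 supplies a size either. No step beyond the scatter is therefore expected in this assay, and the expected change is a number no higher from compound 2 to compound 4 (the limit leaves the size open). Compound 4 is estimated at 20000 nM, with an expected range of 9000 nM to 40000 nM.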

Compound 4, half-maximal effective concentration: > 10000 nM
Compound 4: only a limit was reported (the forecaster's own chance of this, stated with the estimate: 70%); the middle value lies beyond the limit too.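

In this assay, among the compounds shown here, compound 4 gives only a limit, > 10000 nM, and compound 2 also has only a limit, so no step between them can be read. The compounds shown leave open what concentration, if any, gives a half-maximal effect in this assay: all four values are limits.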